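The source may report more compounds than this note shows. Statements on the series, on what has been measured and on what is new or still open speak of the compounds shown alone.

Compound 3 `Cc1ccc(NC2=NCCC3(CCCCC3)S2)cc1` gives 31600 nM in a functional assay on a subcellular fraction from brain (Rattus norvegicus) for inhibition, read by scintillation counting, with a stated time of 5 min (a higher number here means a weaker inhibitor, a lower number a stronger inhibitor), the lowest of the three numbers shown, though its gap to compound 1 lies within the scatter. Compound 1 `c1ccc(NC2=NCCC3(CCCCC3)S2)cc1` gives 63100 nM, and compound 2 `Cc1ccc(NC2=NCCC3(CCCCC3)S2)cc1Cl` gives 89100 nM. The step of a 2.0-fold lower number from compound 1 to compound 3 (0.30 log units; within the scatter) stays within the scatter, whereas a 2.8-fold lower number from compound 2 to compound 3 (0.45 log units; beyond the scatter) goes beyond it. Compound 4 `CCc1ccc(NC2=NCCC3(CCCCC3)S2)cc1` differs from compound 3 by methyl in place of hydrogen on a saturated chain carbon bound to an aromatic carbon. Among the measured compounds shown here, no measured step changes this same place; the only step that adds a methyl anywhere, a 2.0-fold lower number from compound 1 to compound 3 (0.30 log units; within the scatter), stayed within the scatter, so no movement beyond the scatter is expected in this assay here. The step expected here is a 1.3-fold lower number from compound 3 to compound 4 (0.10 log units; within the scatter). Compound 4 is therefore estimated at 25000 nM, with a range from 10000 nM to 63000 nM.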

Compound 4, half-maximal inhibitory concentration: 11700 nM
Beside the measured number, compound 4's estimate is 2.1-fold (0.33 log units) above it, within the range that was stated.
By their numbers in this assay, from the lowest: compound 4; then compounds 3, 1 and 2 (each within the scatter of the next, the first and the last beyond it).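

In this assay, the step of a 2.7-fold lower number from compound 3 to compound 4 (0.43 log units; beyond the scatter) shows that going from methyl to ethyl at this place moves the number beyond the scatter, which the earlier addition of a methyl did not do. Counted from the compound with hydrogen on that aromatic carbon, ethyl gives a 5.4-fold lower number from compound 1 to compound 4 (0.73 log units; beyond the scatter), the largest step seen in this set. Nothing measured here explains why this change matters.

Going by these compounds, whether a longer chain such as propyl lowers the number further remains open. So does the effect of an amine or a carboxylic acid at this place.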